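A few compounds are considered here, and "the series" means these few. Any claim that something is new, unique, unknown or untested is made for them only; others in the source may bear on it.

Measured so far in a physicochemical assay for solubility, at pH 7.4; on this read-out higher numbers stand for higher solubility and lower numbers for lower solubility:
- Compound 1 `Cc1cc(NC(=O)Nc2ccc(C(C)(C)C)cc2)c2ccccc2n1`: 6200 nM
- Compound 2 `Cc1cc(NC(=O)Nc2ccc(SC(F)(F)F)cc2)c2ccccc2n1`: 200 nM

Compound 2, at 200 nM, holds the lower of the two numbers, and the gap to compound 1 lies beyond the scatter. The next compound changes a single group. Compound 3 `Cc1cc(NC(=O)Nc2ccc(C(=O)O)cc2)c2ccccc2n1` has carboxy in place of (trifluoromethyl)sulfanyl on an aromatic carbon, para to a large group: carboxy in place of (trifluoromethyl)sulfanyl on an aromatic carbon.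

For the measured compounds named here, only one measured step bears on this change. It concerns the same aromatic carbon, where tert-butyl gave way to (trifluoromethyl)sulfanyl, and it was large: a 31-fold lower number from compound 1 to compound 2 (1.49 log units; beyond the scatter). A large step is therefore expected in this assay again, because a 31-fold lower number from compound 1 to compound 2 (1.49 log units; beyond the scatter) shows that a swap at this carbon alone can move the number far beyond the scatter. Going by the values given here, no measured compound carries carboxy, so the direction is a judgement rather than a trend, and a rise is the expectation here. The expected change is a 200-fold higher number from compound 2 to compound 3 (2.30 log units; beyond the scatter). For compound 3 the estimated value is 40000 nM, with an expected range of 6000 nM to 200000 nM.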

Compound 3, solubility: 9300 nM
The estimate for compound 3 lay 4.3-fold (0.63 log units) above the measured number, within the range that was stated.
By their numbers in this assay, from the lowest: compound 2; then compounds 1 and 3 (each within the scatter of the next).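

In this assay, replacing (trifluoromethyl)sulfanyl with carboxy on this aromatic carbon gives a 47-fold higher number from compound 2 to compound 3 (1.67 log units; beyond the scatter), so a single swap here can move the number a long way upward as well as downward. Set against the earlier step, the comparison of carboxy with tert-butyl gives a 1.5-fold higher number from compound 1 to compound 3 (0.18 log units; within the scatter), which means that these two groups cannot be told apart on this read-out, while (trifluoromethyl)sulfanyl stands apart from both. Nothing available explains why these three groups fall out this way.

The compounds shown leave open whether the number of compound 3 depends on the free carboxy group, since a methyl ester or a primary amide at the same carbon could stay level with compound 3 or drop toward compound 2. They also leave open where a small group such as a chlorine atom or an amine would fall, and so whether compound 2 is an unusual case or whether many groups at this carbon give numbers as low as its own.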